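The source may hold more compounds than are shown below. What is called first, only, known or untested is meant among the compounds shown, and "the series" means these compounds.

Working notes on the shared core of compound 1 `Nc1cc(N)c2nc(-c3ccccc3)c(NCc3ccc(Cl)c(Cl)c3)nc2c1`, compound 2 `Nc1cc(N)c2nc(-c3ccccc3)c(Oc3ccc(F)cc3)nc2c1` and compound 3 `COc1ccc(CNc2nc3cc(N)cc(N)c3nc2-c2ccccc2)cc1`, all tested in a functional assay on OVCAR-4 cells (Homo sapiens) for inhibition, read by sulforhodamine B assay, with a stated time of 48 h; a higher number here means that more compound is tolerated, a lower number that less compound is tolerated. For compound 1 the value in this assay is a limit of the assay, < 100000 nM. For compound 2 the value in this assay is likewise a limit, < 100000 nM. In this assay compound 3 gives 47900 nM. Among the compounds with values here, the one single-point step in the set, a step that the limit leaves unreadable from compound 1 to compound 3, has no readable size because of the limit of < 100000 nM in this assay, at which 2 of the 3 values shown sit. Compound 2 therefore stands only at a limit, without a number of its own, and one further value among the three is also a limit.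

Compound 4 `COc1ccc(Sc2nc3cc(N)cc(N)c3nc2-c2ccccc2)cc1` differs from compound 2 as follows: (4-methoxyphenyl)sulfanyl in place of 4-fluorophenoxy on an aromatic carbon. Within the data shown here, no measured step bears on this change; the only step in the set exchanges a group on a saturated chain carbon bound to a nitrogen on an aromatic ring, and its size is unreadable. Among the measured compounds shown here, compound 3 carries a 4-methoxyphenyl and gives the only numeric value in the set, 47900 nM. The step that the estimate means, a step that the limit leaves unreadable from compound 2 to compound 4, is expected only loosely, since the starting value is a limit. Compound 4 is expected to sit near 50000 nM, between 15000 nM and 120000 nM, with a fair chance that only a limit is reported.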

Compound 4, concentration lethal to 50% of the cells: < 100000 nM
Compound 4 was reported as a limit (the forecaster's own chance of this, stated with the estimate: 40%); the middle value is on the limit's open side.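

The exchange of 4-fluorophenoxy for (4-methoxyphenyl)sulfanyl gives no readable step from compound 2 to compound 4, because both values are limits: the limit of < 100000 nM in this assay, at which 3 of the 4 values shown sit.

The compounds shown leave open how far these two groups differ in this assay, and where compound 1, compound 2 and compound 4 stand numerically relative to compound 3.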